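Thioamide side chain variation on the pyridazinone core

The source may report more compounds than this note shows. Statements on the series, on what has been measured and on what is new or still open speak of the compounds shown alone.

Compound 1 `CC/N=C(\S)CCn1nc(-c2ccccc2)ccc1=O` is the reference in a functional assay on the whole organism (stomach) for inhibition, with Rattus norvegicus as the target, at a dose of 100 mg/kg by the intraduodenal route (a lower number here means less inhibition, a higher number more inhibition at the dose given (going by the name of the read-out)), where compound 1 gives 50.3%, the second highest of the three numbers in hand. Compound 3 `N=C(S)CCn1ncc2ccccc2c1=O` lies nearest: in this assay compound 3 gives 58.3%, a difference within the scatter. Compound 2 `CC(Cn1ncccc1=S)C(=N)S` is furthest: compound 2 gives -1%, a gap beyond the scatter, though compound 2 also carries a different core, so no single-point comparison exists.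

Compound 4 `CC(Cn1nc(-c2ccccc2)ccc1=O)C(=N)S` differs from compound 1 by a group of 5 heavy atoms (3 carbon, 1 nitrogen, 1 sulfur; no ring) in place of a group of 6 heavy atoms (4 carbon, 1 nitrogen, 1 sulfur; no ring), on a saturated chain carbon bound to an aromatic nitrogen. Going by the values given here, no measured pair isolates this change; the expectation for the step from compound 1 to compound 4 is a number 6.3 percentage points lower from compound 1 to compound 4 (within the scatter), a small downward shift that stays within the scatter. Compound 4 is estimated at 44%, with a range from 20% to 68%.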

Compound 4, a percentage reported as inhibition, in the whole organism at one dose (the size of the read-out at that dose, not a potency): 86.4%
Estimate against measurement, compound 4: 42.4 percentage points below; measured number above the stated range.
By their numbers in this assay, from the lowest: compound 2; then compounds 1 and 3 (each within the scatter of the next); then compound 4.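

On the saturated chain carbon bound to an aromatic nitrogen, the group of 5 heavy atoms in place of the group of 6 heavy atoms gives, in this assay, a number 36.1 percentage points higher from compound 1 to compound 4 (beyond the scatter). Going by these compounds alone, this is the first single-point comparison, and it shows that inhibition at this dose responds strongly to this side chain on an unchanged core. Nothing at hand bears on why the step is so large. Open, as far as these compounds go, is how a longer chain, an amine or a carboxylic acid in this place would compare. From the compounds shown here alone, whether the same change carries over to another core also remains open.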